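The source may report more compounds than this note shows. Statements on the series, on what has been measured and on what is new or still open speak of the compounds shown alone.

Measured so far:
- compound 1 `CC(C)(C)OC(=O)N1CCN(C(=S)SCc2cn(-c3ccccc3F)nn2)CC1`: 89600 nM
- compound 2 `CC(C)(C)OC(=O)N1CCN(C(=S)SCc2cn(Cc3cc(=O)oc4cc(O)ccc34)nn2)CC1`: 10400 nM
- compound 3 `COc1ccc(Cn2cc(CSC(=S)N3CCN(C(=O)OCc4ccccc4)CC3)nn2)cc1`: 30500 nM

All three share the piperazine dithiocarbamate attached through a methylene to a triazole, and all were run in a functional assay on MCF7 cells (Homo sapiens) for inhibition, read by MTT assay, with a stated time of 72 h; a lower number here means a stronger inhibitor, a higher number a weaker inhibitor. Among them compound 1 gives the highest number; the nearest is compound 3 with a value lower by a margin beyond the scatter, and the furthest is compound 2, lower still by a margin also beyond the scatter. Compound 1 is thus the weakest of the three on these numbers. Both compound 2 and compound 3 carry a benzyl-type substituent on the triazole nitrogen, where compound 1 carries an aryl group directly.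

The next compound, compound 4 `CC(C)(C)OC(=O)N1CCN(C(=S)SCc2cn(Cc3ccc(Cl)cc3)nn2)CC1`, has not been measured. It differs from compound 1 in one place: 4-chlorobenzyl in place of 2-fluorophenyl on an aromatic nitrogen. That is, 4-chlorobenzyl in place of 2-fluorophenyl on an aromatic nitrogen. Since compound 3 with its 4-methoxybenzyl gives 30500 nM and compound 2 with its substituted benzyl gives 10400 nM, the change toward a benzyl group is expected to move the number down, moderately, and likely beyond the scatter, as a 2.6-fold lower number from compound 1 to compound 4 (0.41 log units; beyond the scatter). For compound 4 in this assay the estimate is 35000 nM, with a range from 12000 nM to 100000 nM.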

Compound 4, half-maximal inhibitory concentration: 2960 nM
Beside the measured number, compound 4's estimate is 12-fold (1.07 log units) above it, outside the stated range (below it).
By their numbers in this assay, from the lowest: compound 4; then compound 2; then compound 3; then compound 1.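

Among these compounds, until now no two measured compounds differed in one place only, so the part played by the group on the aromatic nitrogen of the triazole could not be read on its own. In this assay that position now proves highly responsive, with a 30-fold lower number from compound 1 to compound 4 (1.48 log units; beyond the scatter) when 4-chlorobenzyl replaces 2-fluorophenyl and the rest of the core of compound 1 stays unchanged. Both groups hold one six-membered aromatic ring of carbon only, so the step does not come from adding or removing a ring, and no measurement at hand explains its size.

Among the compounds shown here, the single step changes the halogen, its place on the ring and the attachment to the triazole nitrogen together, so the share of each stays unresolved. An unsubstituted benzyl group, a chlorophenyl group set directly on the nitrogen, or a longer chain such as phenethyl would separate these contributions, and the compounds shown do not say whether the low number of compound 4 depends on the chlorine, the methylene link or both.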